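The source may hold more compounds than are shown below. What is called first, only, known or untested is meant among the compounds shown, and "the series" means these compounds.

Measured compounds:
compound 1 `CCN1CCN(CC(=O)O[C@@H]2C[C@@H]3CC[C@@]2(C)C3(C)C)CC1`: 100000 nM
compound 2 `CC1(C)[C@H]2CC[C@]1(C)[C@H](OC(=O)CN1CCCCC1)C2`: 138000 nM

The two measured compounds share the same bicyclic ester core and differ only in the amine attached to the chain carbon. In an ADME assay on MDCK cells (Canis lupus familiaris) for cytotoxicity, read by MTT assay, with a stated time of 48 h (a higher number here means that more compound is tolerated, a lower number that less compound is tolerated), compound 1 gives 100000 nM. In this assay compound 2 gives 138000 nM; its number is the larger of the two shown, but the gap to compound 1 lies within the scatter of repeated measurements, so the two compounds are best read as tolerated to a similar degree.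

Compound 3 `CC1(C)[C@H]2CC[C@]1(C)[C@H](OC(=O)CN1CCNCC1)C2` is not yet measured. It differs from compound 2 as follows.
piperazin-1-yl in place of piperidin-1-yl on a saturated chain carbon bound to a carbonyl carbon
The change keeps the ring size and the point of attachment, exchanging one ring carbon for a nitrogen that carries a hydrogen.

Among the measured compounds shown here, no step between measured compounds is available for this kind of exchange. Compound 1, which carries a piperazine ring bearing an ethyl group, sits within the scatter of compound 2, so the amine ring does not appear to move the number much in this set. The step of a 1.3-fold lower number from compound 2 to compound 3 (0.10 log units; within the scatter) is therefore expected to be small, with no direction beyond the scatter. Compound 3 is estimated at 110000 nM, with a range from 50000 nM to 250000 nM.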

Compound 3, half-maximal cytotoxic concentration: 51600 nM
For compound 3 the middle estimate is 2.1-fold (0.33 log units) above the measured one; measured number inside the range.
By their numbers in this assay, from the lowest: compounds 3, 1 and 2 (each within the scatter of the next, the first and the last beyond it).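

In this assay, among the compounds shown here, the exchange of piperidin-1-yl for piperazin-1-yl on a saturated chain carbon bound to a carbonyl carbon gives a 2.7-fold lower number from compound 2 to compound 3 (0.43 log units; beyond the scatter) and so provides the first step at this position that lies beyond the scatter, which shows that the number is not indifferent to the amine ring. Hydrogen in place of ethyl on an amine nitrogen in a ring gives a 1.9-fold lower number from compound 1 to compound 3 (0.29 log units; within the scatter) and this step stays within the scatter, so the two piperazine compounds cannot be told apart on the ring nitrogen substituent. Nothing measured here accounts for the lower number of compound 3.

The compounds shown leave open whether a morpholine ring or an open-chain dimethylamino group on the same chain carbon would stand nearer to compound 2 or to compound 3, and whether a longer chain carrying the piperazine ring would move the number at all. The exchange also rests on a single pair, so it remains unsettled whether the same step would appear on a different ester core.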